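The source may hold more compounds than are shown below. What is called first, only, known or untested is meant among the compounds shown, and "the series" means these compounds.

Compound 1 `COc1cc(-c2nnc(SCc3ccccc3Cl)n2N2C(=O)c3ccccc3C2=O)cc(OC)c1OC` is the chloro-bearing member of the pair. In a functional assay on A549 cells (Homo sapiens) for cytotoxicity, read by MTT assay, with a stated time of 48 h (a lower number here means a stronger inhibitor, a higher number a weaker inhibitor), compound 1 gives only a limit, > 200000 nM. Compound 2 `COc1cc(-c2nnc(SCc3ccccc3)n2N2C(=O)c3ccccc3C2=O)cc(OC)c1OC` carries hydrogen in place of that chloro on the aromatic carbon. In this assay compound 2 likewise gives only a limit, > 200000 nM. The step that the two limits leave unreadable from compound 1 to compound 2 is thus not readable in size. Where compound 2 stands is known only as a limit; the evidence the limit of > 200000 nM in this assay, at which 2 of the 2 values shown sit, shows both measured values resting at that same limit. Compound 3 `COc1cc(-c2nnc(SCC(=O)c3ccc(F)cc3)n2N2C(=O)c3ccccc3C2=O)cc(OC)c1OC` differs from compound 2 by (4-fluorophenyl)carbonyl in place of phenyl on a saturated chain carbon bound to a sulfur. Among the compounds with values here, no measured step bears on this change; the single step is unreadable, and no direction or size can be taken from it for this assay. Compound 3 is therefore expected to remain near the same limit, with the step of an at least 1.1-fold lower number from compound 2 to compound 3 (0.04 log units; that floor lies within the scatter) expected to stay within the scatter. The estimate for compound 3 is 180000 nM, in a range from 40000 nM to 800000 nM.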

Compound 3, half-maximal inhibitory concentration: > 200000 nM
Compound 3: a limit, no number (the forecaster's own chance of this, stated with the estimate: 65%); at least 1.1-fold (0.04 log units) between middle value and limit.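

In this assay compound 3 gives only a limit, > 200000 nM, so its steps from compound 1 and compound 2 cannot be read. The true potency of compound 1, compound 2 and compound 3, and whether either change shifts it, stays open: the limit of > 200000 nM in this assay, at which 3 of the 3 values shown sit.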